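The source may hold more compounds than are shown below. What is called first, only, known or untested is meant among the compounds shown, and "the series" means these compounds.

Compound 1 `COc1cccc2c(=O)c(Cc3ccccc3)c(C)[nH]c12`: > 20000 nM
Compound 2 `Cc1[nH]c2c(Cl)cccc2c(=O)c1Cc1ccccc1`: 5000 nM
Compound 3 `COc1ccc2nc(C)c(Cc3ccccc3)c(OC)c2c1`: 2000 nM

All three were measured in a physicochemical assay for solubility, read by HPLC, at pH 7.4; on this read-out lower numbers stand for lower solubility and higher numbers for higher solubility. The value of compound 1 is a limit of the assay, not a number. Compound 2 differs from compound 1 in one place: chloro in place of methoxy on an aromatic carbon. That change gave an at least 4.0-fold lower number from compound 1 to compound 2 (0.60 log units; beyond the scatter); the step can only be stated as a bound because compound 1 sits at the limit of > 20000 nM in this assay, at which 1 of the 3 values shown sits. Compound 3 is built on a different core; the difference between the cores of compound 1 and compound 3 is not broken down here. Of the two plain numbers, compound 3 gives the lower one, and the gap to compound 2 lies beyond the usual scatter.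

Compound 4 `COc1c(Cc2ccccc2)c(C)nc2ccc(Cl)cc12` has not yet been measured in this assay. It differs from compound 3 in one place: chloro in place of methoxy on an aromatic carbon. For the measured compounds named here, this is the same kind of change as the one from compound 1 to compound 2, but not the same: in compound 2 the chloro sits ortho to a fused ring and meta to a fused ring, whereas in compound 4 it sits meta to a fused ring and para to a fused ring. Resting on an at least 4.0-fold lower number from compound 1 to compound 2 (0.60 log units; beyond the scatter), the step is expected to be a 2.9-fold lower number from compound 3 to compound 4 (0.46 log units; beyond the scatter). The core and the place differ, and the earlier step is only a bound, so a somewhat smaller step is expected. Compound 4 is therefore estimated at 700 nM, most likely between 200 nM and 2500 nM.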

Compound 4, solubility: < 2000 nM
Compound 4: only a limit was reported; the forecaster's own chance of this, stated with the estimate: 5%; the middle value does not contradict the limit.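

In this assay compound 4 gives < 2000 nM, and this value is a limit of the assay, not a number. Chloro in place of methoxy on an aromatic carbon gave a number no higher from compound 3 to compound 4 (the limit leaves the size open), and on a different core it gave an at least 4.0-fold lower number from compound 1 to compound 2 (0.60 log units; beyond the scatter), so the second pair does not go against the direction seen in the first, which is as far as these two pairs reach. This does not show that the change carries over with the same size, and the two steps cannot be compared in size because each of them rests on a limit: the limit of < 2000 nM in this assay, at which 1 of the 4 values shown sits, and (the limit of > 20000 nM in this assay, at which 1 of the 4 values shown sits).

Core and place change together between these two pairs, so the compounds shown cannot tell whether a chloro that sits meta to a fused ring and para to a fused ring on the core of compound 1 would read as it does in compound 4. The changed place holds only methoxy or chloro here, which leaves open how an amine, a carboxylic acid or a longer chain such as ethoxy would read there on either core.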